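A few compounds are considered here, and "the series" means these few. Any claim that something is new, unique, unknown or untested is made for them only; others in the source may bear on it.

Measured so far in a functional assay on Malme-3M cells (Homo sapiens) for inhibition, with a stated time of 48 h; on this read-out higher numbers stand for weaker inhibition of growth and lower numbers for stronger inhibition of growth:
- compound 1 `COc1ccccc1/C=C/C(=O)c1c(O)cc2occc2c1OC` gives 18900 nM
- compound 2 `COc1c(C(=O)/C=C/c2ccc(Cl)cc2)c(O)c(Br)c2occc12` gives 2610 nM
- compound 3 `C=CCc1c(O)c(C(=O)/C=C/c2ccccc2)c(OC)c2ccoc12` gives 5800 nM

Compound 3 (5800 nM) stands in the middle of the three numbers. Compound 2 (2610 nM) lies lower and compound 1 (18900 nM) lies higher, and both gaps from compound 3 are beyond the usual scatter.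

The next compound, compound 4 `C=CCc1c(O)c(C(=O)/C=C/c2ccc(Cl)cc2)c(OC)c2ccoc12`, keeps the core of compound 3 and has chloro in place of hydrogen on an aromatic carbon, para to a large group, so that phenyl becomes 4-chlorophenyl (chloro in place of hydrogen on an aromatic carbon). Among the compounds with values here, no pair of measured compounds differs in one place only, so the size of this step cannot be read from the series and remains a judgement. Compound 2 (2610 nM) also carries the 4-chlorophenyl group and has the lowest number, but it differs from compound 3 in other places too, which makes it only a weak guide.

A small move toward stronger inhibition of growth in this assay is expected, likely within the usual scatter, and the estimated step is a 1.7-fold lower number from compound 3 to compound 4 (0.22 log units; within the scatter) here. For compound 4 the estimated value is 3500 nM, with an expected range from 1400 nM to 9000 nM in this read-out.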

Compound 4, concentration for 50% growth inhibition: 2740 nM
Compound 4: the middle estimate sits 1.3-fold (0.11 log units) above what was measured; measured number inside the range.
By their numbers in this assay, from the lowest: compounds 2 and 4 (each within the scatter of the next); then compound 3; then compound 1.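

In this assay, the series now has its first step at a single place: a 2.1-fold lower number from compound 3 to compound 4 (0.33 log units; beyond the scatter) is a modest move toward stronger inhibition of growth, with chloro in place of hydrogen on an aromatic carbon, para to a large group. The second single-place pair, with allyl in place of bromo on an aromatic carbon, gives a 1.0-fold higher number from compound 2 to compound 4 (0.02 log units; within the scatter) and so does not separate the two groups at that place while the 4-chlorophenyl group is present. No measured property or other supporting data bears on either step, and neither can be tied to a cause.

The compounds shown leave open whether the phenyl to 4-chlorophenyl step keeps its size when bromo replaces allyl, as only the allyl pair reads it directly. They also leave open how a methoxy group or a nitrile would compare with chloro on that aromatic carbon, and how an amine or a longer chain would compare with allyl and bromo at the other place.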